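Benzylamide series: bromo to dichloro at the benzyl ring

The source may hold more compounds than are shown below. What is called first, only, known or untested is meant among the compounds shown, and "the series" means these compounds.

Measured so far in an assay on CHO cells for displacement of a labelled ligand from transient receptor potential cation channel subfamily V member 1 (Rattus norvegicus); a lower number here means a stronger inhibitor, a higher number a weaker inhibitor:
compound 1 `COc1cc(C2(C(=O)NCc3ccc(C(C)(C)C)cc3)CC2)ccc1NS(C)(=O)=O` gives 750 nM
compound 2 `CC(C(=O)NCc1ccc(Cl)cc1)c1ccc(NS(C)(=O)=O)c(F)c1` gives 1060 nM
compound 3 `CC(C(=O)NCc1ccc(Br)cc1)c1ccc(NS(C)(=O)=O)c(F)c1` gives 412 nM

Compound 3 carries the lowest number of the three, but compound 1 stands within the usual scatter of it, so no order between those two is claimed; only compound 2 is separated, by a 2.6-fold lower number from compound 2 to compound 3 (0.41 log units; beyond the scatter).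

Compound 4 `CC(C(=O)NCc1ccc(Cl)c(Cl)c1)c1ccc(NS(C)(=O)=O)c(F)c1` is not yet measured. It differs from compound 3 in one place: 3,4-dichlorophenyl in place of 4-bromophenyl on a saturated chain carbon bound to an amide-type nitrogen. Within the data shown here, the only measured step that touches this ring is the halogen swap from compound 2 to compound 3, a 2.6-fold lower number from compound 2 to compound 3 (0.41 log units; beyond the scatter), a modest change. Among the measured compounds shown here, nothing measured here speaks to a second chlorine on that ring, so the expectation rests on the single halogen step alone. Compound 4 is therefore expected to stay close to compound 3, with no step beyond the scatter foreseen: a 1.0-fold higher number from compound 3 to compound 4 (0.01 log units; within the scatter). The estimate for compound 4 in this assay is 420 nM, with a range from 150 nM to 1200 nM.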

Compound 4, inhibition constant: 200 nM
Beside the measured number, compound 4's estimate is 2.1-fold (0.32 log units) above it; low and high end bracket the measured number.
By their numbers in this assay, from the lowest: compound 4; then compounds 3, 1 and 2 (each within the scatter of the next, the first and the last beyond it).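

In this assay, among these compounds, chloro in place of hydrogen on an aromatic carbon gives a 5.3-fold lower number from compound 2 to compound 4 (0.72 log units; beyond the scatter), the first measured change at this group that adds a substituent rather than swapping one halogen for another. Moving from 4-bromophenyl to 3,4-dichlorophenyl gives a 2.1-fold lower number from compound 3 to compound 4 (0.31 log units; beyond the scatter), so compound 3 does not mark the lowest number reachable at this group on the shared core. The data offer no explanation for either step.

From the compounds shown here alone, it remains open whether the second chlorine could be replaced by a trifluoromethyl or a nitrile with the same outcome. Going by these compounds, compound 1 differs from the others in more than one place, so it remains open how its tert-butyl group would compare with 3,4-dichlorophenyl on the core of compound 4.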